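From Pyridin-4-yl to Pyrazin-2-yl on the Ring Nitrogen

This account rests on a few compounds, and the source may have more. Where it says the series, first, only, none or still open, it means among the compounds named here.

Of the compounds shown here, three have been measured in a functional assay on A-375 cells (Homo sapiens) for antiproliferative activity, read by CCK-8 assay, with a stated time of 72 h, tested at 8 uM; on this read-out higher numbers stand for a stronger effect at the one concentration tested and lower numbers for a weaker effect. Compound 1 `Nc1ccccc1NC(=O)c1ccc(CSC(=S)N2CCN(Cc3ccccn3)CC2)cc1` gives 82.4%, compound 2 `CN(Cc1ccncc1)C(=S)SCc1ccc(C(=O)Nc2ccccc2N)cc1` gives 86.1%, and compound 3 `Nc1ccccc1NC(=O)c1ccc(CSC(=S)N2CCN(c3ccncc3)CC2)cc1` gives 90.7%, the highest of the three numbers, although its gaps to compound 2 and to compound 1 both lie within the scatter. Compound 4 `Nc1ccccc1NC(=O)c1ccc(CSC(=S)N2CCN(c3cnccn3)CC2)cc1` differs from compound 3 in one place: pyrazin-2-yl in place of pyridin-4-yl on an amine nitrogen in a ring. Within the data shown here, one measured step bears on this position, the same amine nitrogen in a ring: a number 8.3 percentage points higher from compound 1 to compound 3 (within the scatter). Because a number 8.3 percentage points higher from compound 1 to compound 3 (within the scatter) stayed within the scatter, compound 4 is expected to shift by no more than the scatter as well, a number 3.7 percentage points lower from compound 3 to compound 4 (within the scatter). Compound 4 is therefore estimated at 87%, with a likely range from 75% to 95%.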

Compound 4, a percentage reported as inhibition, at one concentration (the size of the read-out at that concentration, not a potency): 85.8%
For compound 4 the middle estimate is 1.2 percentage points above the measured one, within the range that was stated.
By their numbers in this assay, from the lowest: compounds 1, 4, 2 and 3 (each within the scatter of the next).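

Pyrazin-2-yl, with 2 hetero atoms in its ring rather than the 1 in pyridin-4-yl, gives a number 4.9 percentage points lower from compound 3 to compound 4 (within the scatter), so adding a ring nitrogen to this aromatic group causes no change beyond the scatter. Set against (pyridin-2-yl)methyl, the same group gives a number 3.4 percentage points higher from compound 1 to compound 4 (within the scatter), so all three groups compared on this amine nitrogen read alike at the one concentration tested. Nothing measured here offers an explanation for these readings.

Still open, as far as these compounds go, is whether a phenyl ring with no ring nitrogen, or a carboxylic acid on a short chain, would stay within this range. A single concentration also cannot show whether these compounds differ in potency.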